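This account rests on a few compounds, and the source may have more. Where it says the series, first, only, none or still open, it means among the compounds named here.

Compound 1 `Cc1ccc(C)c(-c2nc(CN3CCC(C(=O)NCCCN4C[C@H](C)C[C@H](C)C4)CC3)c(C)o2)c1` gives 0.5 h in an ADME assay on microsomes from liver (Rattus norvegicus) for metabolic stability, read by LC-MS, using NADPH, at 37 degrees C (on this read-out higher numbers stand for a longer-lived compound and lower numbers for a shorter-lived compound), the higher of the two numbers in hand. Compound 2 `Cc1cccc(Cl)c1-c1nc(CN2CCC(C(=O)NCCCN3CCC(C(C)C)CC3)CC2)c(C)o1` gives 0.0333 h in this assay, a gap beyond the scatter. Compound 3 `Cc1cc(C)cc(-c2nc(CN3CCC(C(=O)NCCCN4C[C@H](C)C[C@H](C)C4)CC3)c(C)o2)c1` is not yet measured; it differs from compound 1 as follows: 3,5-dimethylphenyl in place of 2,5-dimethylphenyl on an aromatic carbon. Among the compounds with values here, no measured pair shows this change, so the expected step from compound 1 to compound 3 is a 1.4-fold lower number from compound 1 to compound 3 (0.15 log units; within the scatter), a small move, likely within the scatter and if anything downward. For compound 3 the estimate in this assay is 0.35 h, with a range from 0.1 h to 1.2 h.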

Compound 3, half-life: < 0.5 h
Compound 3 gave a limit, no number (the forecaster's own chance of this, stated with the estimate: 5%); the middle value is on the limit's open side.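

In this assay compound 3 gives < 0.5 h, a limit and not a number. Within the data shown here, this is the first read on the aryl group at this position, with the same atoms joined differently: 3,5-dimethylphenyl in place of 2,5-dimethylphenyl gives a number no higher from compound 1 to compound 3 (the limit leaves the size open). This change therefore shows no gain in half-life, and its size stays unreadable: the limit of < 0.5 h in this assay, at which 1 of the 3 values shown sits.

Still open, going by these compounds, is how far the half-life moves with this change, if it moves at all. Also open, on these data alone, is how a phenyl bearing a methoxy group or a single fluorine would read at this position.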